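Swapping the aryl ring for a hexyl chain

This account rests on a few compounds, and the source may have more. Where it says the series, first, only, none or still open, it means among the compounds named here.

Compound 1 `CC(C)(C)N(NC(=O)c1ccccc1I)C(=O)c1ccccc1Cl`: in an assay on cells for agonist activity at ecdysone receptor (Bombyx mori), read by a luciferase reporter, with a stated time of 24 h (on this read-out higher numbers stand for an effect only at larger amounts of compound and lower numbers for an effect already at smaller amounts), compound 1 gives 1290 nM.
Compound 2 `Cc1cccc(C(=O)NN(C(=O)c2ccccc2Cl)C(C)(C)C)c1C`: in this assay compound 2 gives 20 nM.

Among the measured compounds shown here, compound 2 holds the lower of the two numbers, set apart by the single measured step, a 65-fold lower number from compound 1 to compound 2 (1.81 log units; beyond the scatter). Compound 3 `CCCCCCC(=O)NN(C(=O)c1ccccc1Cl)C(C)(C)C` differs from compound 2 by hexyl in place of 2,3-dimethylphenyl on a carbonyl carbon. For the measured compounds named here, no measured step exchanges an aromatic ring for a chain, so that one step does not bear on this change directly; it only shows how strongly this position sways this assay. Compound 3 is therefore expected to give a clearly higher number, a 75-fold higher number from compound 2 to compound 3 (1.88 log units; beyond the scatter). The estimate for compound 3 is 1500 nM, within 200 nM to 15000 nM.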

Compound 3, half-maximal effective concentration: 741 nM
Compound 3: middle estimate off by 2.0-fold (0.31 log units), on the high side, within the range that was stated.
By their numbers in this assay, from the lowest: compound 2; then compounds 3 and 1 (each within the scatter of the next).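

In this assay, the hexyl chain on this carbonyl carbon falls well short of the 2,3-dimethylphenyl ring (a 37-fold higher number from compound 2 to compound 3 (1.57 log units; beyond the scatter)). Yet it cannot be told apart from the 2-iodophenyl ring (a 1.7-fold lower number from compound 1 to compound 3 (0.24 log units; within the scatter)), so having an aromatic ring here does not by itself give a low number: what the ring carries matters, at least across these compounds. Nothing available explains either step. Still open, on these data alone, is how a shorter butyl chain, a longer octyl chain or a non-aromatic cyclohexyl ring would compare at this position.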